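This account rests on a few compounds, and the source may have more. Where it says the series, first, only, none or still open, it means among the compounds named here.

Measured in a functional assay on ASPC1 cells (Homo sapiens) for inhibition, read by MTT assay, with a stated time of 72 h; on this read-out lower numbers stand for stronger inhibition of growth and higher numbers for weaker inhibition of growth:
- compound 1 `CC(C)(C)c1ccc(CNCCCNS(=O)(=O)c2cc(C(F)(F)F)cc(C(F)(F)F)c2)cc1`: 2700 nM
- compound 2 `O=S(=O)(NCCCNCc1ccc(Cl)c(Cl)c1)c1cc(C(F)(F)F)cc(C(F)(F)F)c1`: 2800 nM
- compound 3 `O=S(=O)(NCCCNCc1ccc(-c2ccccc2)cc1)c1cc(C(F)(F)F)cc(C(F)(F)F)c1`: 2500 nM

All three compounds share one core, a sulfonamide carrying two trifluoromethyl groups, joined through a three-carbon chain to an amine that bears a substituted benzyl group. They differ only in the substituent on that benzyl ring. Compound 3 gives the lowest of the three numbers in this assay, but its nearest neighbour, compound 1, and its furthest, compound 2, both sit within the scatter of it, so no order among the three can be claimed.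

Compound 4 `COc1ccc(CNCCCNS(=O)(=O)c2cc(C(F)(F)F)cc(C(F)(F)F)c2)cc1` continues this series: methoxy in place of phenyl on an aromatic carbon. The two steps that bear on it are a 1.0-fold higher number from compound 1 to compound 2 (0.02 log units; within the scatter) and a 1.1-fold lower number from compound 1 to compound 3 (0.03 log units; within the scatter), both exchanges of the substituent on the same aromatic carbon, and both within the scatter. On that basis a change at this position is expected to leave the number in this assay essentially unchanged, whatever group is introduced. The expected step is therefore a 1.1-fold higher number from compound 3 to compound 4 (0.03 log units; within the scatter), with no direction beyond the scatter. Compound 4 is estimated at 2700 nM, within a range from 1200 nM to 6500 nM.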

Compound 4, concentration for 50% growth inhibition: 2800 nM
Estimate against measurement, compound 4: 1.0-fold (0.02 log units) below; measured number inside the range.
By their numbers in this assay, from the lowest: compounds 3, 1, 2 and 4 (each within the scatter of the next).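

In this assay the group on this aromatic carbon can shrink from phenyl, with 6 heavy atoms and a ring, to methoxy, with 2 heavy atoms, no ring and 1 hydrogen-bond acceptor, and the result is still only a 1.1-fold higher number from compound 3 to compound 4 (0.05 log units; within the scatter). The other two comparisons read the same way, with no change at the digits printed from compound 2 to compound 4 (within the scatter) for 4-methoxyphenyl in place of 3,4-dichlorophenyl and a 1.0-fold higher number from compound 1 to compound 4 (0.02 log units; within the scatter) for methoxy in place of tert-butyl, so across these four compounds neither the size of the group, nor a ring in it, nor the presence of oxygen goes with any difference that can be told from the scatter. Nothing measured here accounts for this flat picture.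

From the compounds shown here alone, it remains open whether the same holds for a group of a different kind on this aromatic carbon, such as an amine or a carboxylic acid. All four compounds also keep the same three-carbon chain and both trifluoromethyl groups, so they cannot say whether a longer chain, or another group in place of trifluoromethyl, would move the number.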